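Trifluoromethyl to difluoromethyl on the anilide of compound 2

The compounds below may be only part of what the source reports. "The series", "measured", "known", "first", "only" and "open" are said of these compounds alone.

Measured so far in an assay on SK-OV-3 cells for inhibition of Indoleamine 2,3-dioxygenase 1 (Homo sapiens); a lower number here means a stronger inhibitor, a higher number a weaker inhibitor:
compound 1, `O=C(Nc1ccc(Cl)cc1F)C(=O)N1CCC(c2ccnc3ccc(F)cc23)CC1`: 7 nM
compound 2, `O=C(Nc1ccc(C(F)(F)F)cc1)C(=O)N1CCC(c2ccnc3ccc(F)cc23)CC1`: 90 nM

Within the data shown here, compound 2 stands at the higher of the two numbers in this assay; the only step that connects it to another measured compound is a 13-fold higher number from compound 1 to compound 2 (1.11 log units; beyond the scatter), which exchanged the whole aryl group on the amide-type nitrogen.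

Compound 3, `O=C(Nc1ccc(C(F)F)cc1)C(=O)N1CCC(c2ccnc3ccc(F)cc23)CC1`, keeps the shared core and the aryl group of compound 2 and differs from it only in hydrogen in place of fluoro on a saturated chain carbon bound to an aromatic carbon and two fluorine atoms, in other words trifluoromethyl to difluoromethyl, 4-(trifluoromethyl)phenyl to 4-(difluoromethyl)phenyl. Among the measured compounds shown here, no measured step touches this substituent: the one step known, from an aryl exchange, speaks to a far larger change and gives no guide to the loss of a single fluorine. With nothing to point either way, the expected step in this assay is a 1.1-fold lower number from compound 2 to compound 3 (0.02 log units; within the scatter), that is no change beyond the scatter. Compound 3 is therefore estimated at 85 nM, with a range of 30 nM to 260 nM.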

Compound 3, half-maximal inhibitory concentration: 21 nM
For compound 3 the middle estimate is 4.0-fold (0.61 log units) above the measured one, and the stated range ends above it.
By their numbers in this assay, from the lowest: compound 1; then compound 3; then compound 2.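

In this assay, the exchange of a single fluoro for hydrogen on this saturated chain carbon proves far from silent, giving (a 4.3-fold lower number from compound 2 to compound 3 (0.63 log units; beyond the scatter)), whereas the earlier step had exchanged the whole aryl group and could not single out this carbon. The 4-(difluoromethyl)phenyl group thus recovers part of the loss seen in the earlier step (a 13-fold higher number from compound 1 to compound 2 (1.11 log units; beyond the scatter)), yet it still falls short of the 4-chloro-2-fluorophenyl group, with (a 3.0-fold higher number from compound 1 to compound 3 (0.48 log units; beyond the scatter)), so the aryl group of compound 1 keeps its lead over both fluorinated methyl variants. Nothing in hand accounts for why the removal of one fluorine moves the number this far.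

The compounds shown leave open whether the trend runs on through monofluoromethyl and methyl at the same place or reverses, and whether a hydroxymethyl or a difluoromethoxy group would fit the same series. They also leave open whether the ring fluoro of compound 1, joined to the difluoromethyl group of compound 3, would add to the gain or bring no further change.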